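The source may hold more compounds than are shown below. What is called first, only, known or untested is meant among the compounds shown, and "the series" means these compounds.

Three compounds of one shared core, which differ only in the substituents on the attached six-membered carbon ring, have been tested in a functional assay on the whole organism with Rattus norvegicus as the target, at a dose of 20 mg/kg by the intraperitoneal route; a higher number here means more inhibition at the dose given (going by the name of the read-out), a lower number less inhibition. Compound 1 `CCc1ccccc1-c1nc(N)nc(N)n1` gives 20% in this assay. Compound 2 `Nc1nc(N)nc(-c2cc(F)ccc2Cl)n1` gives 78%. Compound 3 `Nc1nc(N)nc(-c2cccc(F)c2)n1` gives 70%, the second highest of the three numbers: its nearest neighbour is compound 2, higher by a margin that is within the scatter, and its furthest is compound 1, lower by a margin that is beyond it. Going by the values given here, the one single-change step on record, a number 8 percentage points lower from compound 2 to compound 3 (within the scatter), involves hydrogen in place of chloro on an aromatic carbon and is within the scatter.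

Compound 4 `Nc1nc(N)nc(-c2cccc(Cl)c2)n1` is the next compound, not yet measured. It differs from compound 3 by chloro in place of fluoro on an aromatic carbon. Among the compounds with values here, no measured step exchanges fluoro for chloro, and the only step that touches a chloro group, a number 8 percentage points lower from compound 2 to compound 3 (within the scatter), lies within the scatter, so no shift beyond the scatter is expected from compound 3 to compound 4, that is a number 2 percentage points lower from compound 3 to compound 4 (within the scatter). Compound 4 is therefore estimated to give about 68% in this assay, most likely between 45% and 88%.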

Compound 4, a percentage reported as inhibition, in the whole organism at one dose (the size of the read-out at that dose, not a potency): 100%
Compound 4: middle estimate off by 32 percentage points, on the low side; the measured number lies above the stated range.
By their numbers in this assay, from the lowest: compound 1; then compounds 3 and 2 (each within the scatter of the next); then compound 4.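

In this assay, going by these compounds alone, the exchange of fluoro for chloro on an aromatic carbon, meta to a group of 8 heavy atoms, comes with a number 30 percentage points higher from compound 3 to compound 4 (beyond the scatter), the first single-change step on record to lie beyond the scatter. This position therefore responds to which halogen it carries, even though one heavy atom replaces one heavy atom and the hydrogen-bond donor and acceptor counts of the two groups are the same. Nothing on hand accounts for the size of this step.

Going by these compounds, it remains open whether a methyl, a methoxy or a trifluoromethyl group at this position would keep the number near that of compound 4 or bring it back towards that of compound 3. A reading at one dose also leaves the potency of compound 4 undefined.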